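A Hydroxypropyl Tail Tried on Two Different Cores

The source may hold more compounds than are shown below. What is called first, only, known or untested is meant among the compounds shown, and "the series" means these compounds.

Compound 2 `CC[C@@H]1C(=O)N(C)c2cnc(Nc3ccc(S(N)(=O)=O)cc3)nc2N1C1CCCC1` and compound 1 `CC[C@@H]1C(=O)N(C)c2cnc(Nc3ccc(S(=O)(=O)NCCCO)cc3)nc2N1C1CCCC1` share one core and differ at a single spot: 3-hydroxypropyl in place of hydrogen on a sulfonamide nitrogen. In a functional assay on MCF7 cells (Homo sapiens) for antiproliferative activity, read by CCK-8 assay, with a stated time of 72 h (on this read-out lower numbers stand for stronger inhibition of growth and higher numbers for weaker inhibition of growth), compound 2 gives 394 nM, and compound 1 gives 363 nM, so that a 1.1-fold lower number from compound 2 to compound 1 (0.04 log units; within the scatter). Compound 3 `CCC1C(=O)N(C)c2cnc(Nc3ccc(S(N)(=O)=O)cc3)nc2N1c1ccn(C)n1` is built on another core, and the difference between the two cores is not broken down here. In this assay compound 3 gives 36600 nM. Compound 4 `CCC1C(=O)N(C)c2cnc(Nc3ccc(S(=O)(=O)NCCCO)cc3)nc2N1c1ccn(C)n1` repeats the earlier change on this second core: 3-hydroxypropyl in place of hydrogen on a sulfonamide nitrogen. The place is described in the same words, so this is the same change. Because the earlier step of a 1.1-fold lower number from compound 2 to compound 1 (0.04 log units; within the scatter) stayed within scatter, compound 4 is expected to show a step of about a 1.1-fold lower number from compound 3 to compound 4 (0.04 log units; within the scatter). Compound 4 is therefore estimated at 33000 nM, most likely between 12000 nM and 90000 nM.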

Compound 4, concentration for 50% growth inhibition: 21600 nM
Compound 4: the middle estimate sits 1.5-fold (0.18 log units) above what was measured; the range from low to high includes it.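

On the second core, the 3-hydroxypropyl change gives a 1.7-fold lower number from compound 3 to compound 4 (0.23 log units; within the scatter), so in this assay it again produces no clear shift in growth inhibition. Set side by side, the two steps agree: the same change on two cores in this assay, a 1.1-fold lower number (0.04 log units; within the scatter) from compound 2 to compound 1 and a 1.7-fold lower number (0.23 log units; within the scatter) from compound 3 to compound 4, 1.6-fold (0.19 log units) apart, within the scatter of two such steps. This shows that a change with no clear effect on one core also had none on a second, but two pairs cannot show that this would hold on every core in the series, and they do not explain the result.

As far as these compounds go, it remains open whether a longer chain or an amine in place of 3-hydroxypropyl on a sulfonamide nitrogen would also leave the number unmoved. From the compounds shown here alone, it also remains open which part of the difference between the two cores matters for this read-out.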